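Removing the chloro group from compound 1

The source may hold more compounds than are shown below. What is called first, only, known or untested is meant among the compounds shown, and "the series" means these compounds.

Measured compounds:
compound 1 `Nc1ccccc1NC(=O)/C=C/c1ccc(COCNc2nc(Nc3cccc(Cl)c3)c3ncn(C4CCCC4)c3n2)cc1` — 9.67%
compound 2 `Nc1ccccc1NC(=O)c1ccc(COCNc2nc(Nc3cccc(Cl)c3)c3ncn(C4CCCC4)c3n2)cc1` — 32.6%

In a functional assay on HepG2 cells (Homo sapiens) for antiproliferative activity, read by CCK-8 assay, with a stated time of 72 h, tested at 2 uM (on this read-out lower numbers stand for a weaker effect and higher numbers for a stronger effect at the one concentration tested), compound 1 stands at the lower of the two measured numbers, with 9.67%. Going by the values given here, its only measured neighbour is compound 2, which gives 32.6%; the step of a number 22.9 percentage points higher from compound 1 to compound 2 (beyond the scatter) concerns the group that carries the amide, not the chloro-bearing ring, so it speaks only to how far the read-out can move and not to the change considered here.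

Compound 3 `Nc1ccccc1NC(=O)/C=C/c1ccc(COCNc2nc(Nc3ccccc3)c3ncn(C4CCCC4)c3n2)cc1` is compound 1 with one difference: hydrogen in place of chloro on an aromatic carbon. Among the compounds with values here, no measured pair shows this change, so there is nothing in the data to push the expectation up or down. The account therefore expects a step of a number 1.3 percentage points higher from compound 1 to compound 3 (within the scatter), that is, nothing beyond the scatter. For compound 3 in this assay the estimate is 11%, with a range from 0% to 26%, reflecting the weak read-out of compound 1 and the absence of any measured guide for this change.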

Compound 3, a percentage reported as inhibition, at one concentration (the size of the read-out at that concentration, not a potency): 2.93%
Estimate against measurement, compound 3: 8.1 percentage points above; measured number inside the range.
By their numbers in this assay, from the lowest: compounds 3 and 1 (each within the scatter of the next); then compound 2.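

Within this assay the change from 3-chlorophenyl to phenyl gives a number 6.7 percentage points lower from compound 1 to compound 3 (within the scatter) and so offers the first measured reading at this place, on an aromatic carbon of the six-membered ring meta to a large group. Here, chloro and hydrogen cannot be told apart at the one concentration tested, so the data give no sign that the chloro group matters for this read-out. This reading holds only for compounds that carry the 2-((2-aminophenyl)carbamoyl)ethenyl group, and nothing in hand explains it.

The compounds shown leave open whether hydrogen in place of chloro would read the same way on compound 2 at 32.6% in this assay, where the 2-((2-aminophenyl)carbamoyl)ethenyl group is replaced by (2-aminophenyl)carbamoyl. They also leave open whether a methoxy group, an amine or a carboxylic acid on the same aromatic carbon would move the read-out beyond the scatter, or whether this place stays as silent for those groups as it does for chloro and hydrogen.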